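Neopentylcarbonyl in place of acetyl on a piperazine amide

This account rests on a few compounds, and the source may have more. Where it says the series, first, only, none or still open, it means among the compounds named here.

Measured compounds:
compound 1, `CS(=O)(=O)N(CC1CC1)c1ccccc1N1CCN(C(=O)[C@H](CC(=O)N2CCN(CC3CC3)CC2)Cc2ccc(Cl)cc2)CC1`, > 10000 nM in a functional assay with Melanocortin receptor 4 (Homo sapiens) as the target, read by cAMP accumulation; on this read-out lower numbers stand for an effect already at smaller amounts and higher numbers for an effect only at larger amounts of compound
compound 2, `CC(=O)N1CCN(C(=O)C[C@H](Cc2ccc(Cl)cc2)C(=O)N2CCN(c3ccccc3N(CC3CC3)S(C)(=O)=O)CC2)CC1`, > 10000 nM in this assay

Compound 2 stands at the limit of this assay, so its value is not a number but a limit. Compound 1 also stands at a limit of this assay. Going by the values given here, the one step that joins the two measured compounds, a step that the two limits leave unreadable from compound 1 to compound 2, is therefore of unreadable size; all that can be said is the limit of > 10000 nM in this assay, at which 2 of the 2 values shown sit.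

The unmeasured compound 3, `CC(C)(C)CC(=O)N1CCN(C(=O)C[C@H](Cc2ccc(Cl)cc2)C(=O)N2CCN(c3ccccc3N(CC3CC3)S(C)(=O)=O)CC2)CC1`, differs from compound 2 by tert-butyl in place of hydrogen on a saturated chain carbon bound to a carbonyl carbon; cut one bond further out, the change reads acetyl to neopentylcarbonyl. Among the compounds with values here, no measured step bears on this change: the only step recorded sits between two limits and cannot be read. With both measured values at the limit and nothing that would point toward a number inside the range of this assay, compound 3 is expected to remain at or near the limit, and the step that the limit leaves unreadable from compound 2 to compound 3 is expected to be none beyond the scatter. The estimate for compound 3 is therefore 20000 nM, with a range from 5000 nM to 80000 nM, most likely reported again only as a limit.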

Compound 3, half-maximal effective concentration: 74 nM
Compound 3: the middle estimate sits 270-fold (2.43 log units) above what was measured, outside the stated range (below it).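

Going by these compounds alone, at the saturated chain carbon bound to a carbonyl carbon, the earlier compounds gave no number in this assay, but this position now proves able to carry a large change: tert-butyl in place of hydrogen gives an at least 130-fold lower number from compound 2 to compound 3 (2.13 log units; beyond the scatter). Within the data shown here, the other readable step, an at least 130-fold lower number from compound 1 to compound 3 (2.13 log units; beyond the scatter), is of similar printed size, so the same conclusion is reached from both of the earlier compounds. The step between those two earlier compounds still cannot be read, and compound 3 alone carries a number rather than a limit: the limit of > 10000 nM in this assay, at which 2 of the 3 values shown sit.

From the compounds shown here alone, both readable steps start from a limit, so their true size remains open, and a single compound cannot show how much of the neopentyl group the effect requires. Whether a shorter branched chain such as isopropyl, a ring such as cyclohexyl, or a carboxylic acid or an amine at the end of the acyl chain would also give a number in this assay is left open as well.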